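Small Steps at One Side Chain

A few compounds are considered here, and "the series" means these few. Any claim that something is new, unique, unknown or untested is made for them only; others in the source may bear on it.

Compound 1 `COc1ccc(/C=C\c2cc(OC)c(OC)c(OC)c2)cc1OCc1ccc(C=O)cc1`: 41000 nM
Compound 2 `COc1ccc(/C=C\c2cc(OC)c(OC)c(OC)c2)cc1OCc1ccc(CN2CC[C@H](C(=O)O)C2)cc1`: > 50000 nM
Compound 3 `COc1ccc(/C=C\c2cc(OC)c(OC)c(OC)c2)cc1OCc1ccc(CNCCN(C)C)cc1`: 35000 nM

These compounds were tested in an ADME assay on NCM460 cells (Homo sapiens) for cytotoxicity, read by CCK-8 assay, with a stated time of 48 h; on this read-out lower numbers stand for stronger inhibition and higher numbers for weaker inhibition. Compound 2 stands at the limit of > 50000 nM in this assay, at which 1 of the 3 values shown sits, so its result is a limit and not a number. Compound 4 `COc1ccc(/C=C\c2cc(OC)c(OC)c(OC)c2)cc1OCc1ccc(CN2CCCCC2C(=O)NCCN)cc1` differs from compound 2 on a saturated chain carbon bound to an aromatic carbon: 2-((2-aminoethyl)carbamoyl)piperidin-1-yl in place of 3-carboxypyrrolidin-1-yl on a saturated chain carbon bound to an aromatic carbon. Three measured steps changed the group at this same place: an at least 1.2-fold higher number from compound 1 to compound 2 (0.08 log units; that floor lies within the scatter), a 1.2-fold lower number from compound 1 to compound 3 (0.07 log units; within the scatter) and an at least 1.4-fold lower number from compound 2 to compound 3 (0.15 log units; that floor lies within the scatter). The last is the closest guide, as it also replaces 3-carboxypyrrolidin-1-yl. All three are small, so only a modest move towards a lower number is expected. The expected step is an at least 1.3-fold lower number from compound 2 to compound 4 (0.11 log units; that floor lies within the scatter). For compound 4 the estimated value is 38000 nM, with an expected range of 18000 nM to 65000 nM.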

Compound 4, half-maximal inhibitory concentration: > 50000 nM
Compound 4: only a limit was reported (the forecaster's own chance of this, stated with the estimate: 35%); middle value at least 1.3-fold (0.11 log units) from the limit.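

In this assay compound 4 gives only a limit, the same one that compound 2 gives, so swapping in the larger 2-((2-aminoethyl)carbamoyl)piperidin-1-yl group brings no readable change at this saturated chain carbon: the limit of > 50000 nM in this assay, at which 2 of the 4 values shown sit. The step between these two limits cannot be read. Going by these compounds alone, the one readable step is an at least 1.4-fold higher number from compound 3 to compound 4 (0.15 log units; that floor lies within the scatter) and so shows no clear separation at this position.

The compounds shown leave open whether a morpholine ring or a carboxylic acid on a longer chain would give a clearly lower number. They also leave open how far compound 2 and compound 4 actually lie from each other.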